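The source may report more compounds than this note shows. Statements on the series, on what has been measured and on what is new or still open speak of the compounds shown alone.

Measured in a functional assay on the whole organism with Mus musculus as the target, in the maximal electroshock model; a higher number here means that more compound is needed for the effect, a lower number that less compound is needed:
- compound 1 `OC1CCN(c2ccc(-c3ccc(Cl)cc3)nn2)CC1`: 29 mg/kg
- compound 2 `O=[N+]([O-])c1ccccc1-c1ccc(N2CCC(O)CC2)nn1`: 27 mg/kg
- compound 3 `Cc1ccccc1-c1ccc(N2CCC(O)CC2)nn1`: 30 mg/kg

The three values lie within the usual scatter of one another. At 30 mg/kg, compound 3 therefore cannot be separated from compound 1 or compound 2 in this assay.

The next compound is compound 4 `Cc1cc(Cl)ccc1-c1ccc(N2CCC(O)CC2)nn1`, which differs from compound 3 by one substitution: chloro in place of hydrogen on an aromatic carbon, meta to a methyl group and para to a large group (chloro in place of hydrogen on an aromatic carbon).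

Among the measured compounds shown here, only one measured step bears on this directly, and it is at a different place and involves different groups. This is a 1.1-fold higher number from compound 2 to compound 3 (0.05 log units; within the scatter), which stays within the scatter. Compound 1, with 29 mg/kg, also carries a chloro group but lacks the methyl group, and its value is within the scatter of that of compound 3. For the measured compounds named here, no measured compound shows a chloro change on its own, so the evidence is indirect, but nothing in these data points to a large shift.

No step beyond the scatter is therefore expected in this assay, and the expected result is a 1.1-fold lower number from compound 3 to compound 4 (0.05 log units; within the scatter). For compound 4 the estimated value is 27 mg/kg, with an expected range of 13 mg/kg to 55 mg/kg.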

Compound 4, dose for half-maximal effect: 10 mg/kg
For compound 4 the middle estimate is 2.7-fold (0.43 log units) above the measured one; measured number below the stated range.
By their numbers in this assay, from the lowest: compound 4; then compounds 2, 1 and 3 (each within the scatter of the next).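

In this assay, chloro in place of hydrogen on the aromatic carbon meta to a methyl group and para to a large group gives a 3.0-fold lower number from compound 3 to compound 4 (0.48 log units; beyond the scatter) and so produces the first step beyond the scatter among these compounds, with less compound needed for the effect. The methyl group counts as well when the chloro group is already present: methyl in place of hydrogen gives a 2.9-fold lower number from compound 1 to compound 4 (0.46 log units; beyond the scatter) and arrives at the same compound by the other route, so both single changes to the aromatic ring are now seen to lower the number by a modest step once the other group is in place. What lies behind these two steps cannot be said from the material at hand, which holds no measurement that bears on it.

The compounds shown leave open how either group behaves on an aromatic ring that carries hydrogen in the place of the other, so it cannot be told whether the two steps depend on the pair. They also leave open whether fluoro, bromo or methoxy in the place of the chloro group would give a step of the same size.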